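Selenium substituent series: methyl to hydrogen on selenium

The source may hold more compounds than are shown below. What is called first, only, known or untested is meant among the compounds shown, and "the series" means these compounds.

Compound 1 `COc1ccc(CNc2nc([Se]C)nc3ccccc23)cc1` is the weaker of the two compounds for which a number exists in a functional assay on HT-29 cells (Homo sapiens) for cytotoxicity, read by MTT assay, with a stated time of 72 h (a lower number here means a stronger inhibitor of growth, a higher number a weaker inhibitor of growth), where compound 1 gives 73600 nM. The nearest neighbour on the numbers is compound 2 `C[Se]c1nc(N)c2ccccc2n1`, which in this assay gives 27600 nM, a gap that lies beyond the scatter of repeated measurements. Compound 3 `CCCCC[Se]c1nc([Se]CCCCC)c2cccnc2n1` gives only a limit in this assay, > 100000 nM, and no number. One of the three values shown therefore sits at the upper limit of the measurement, as recorded in the limit of > 100000 nM in this assay, at which 1 of the 3 values shown sits. Among the compounds with values here, no pair among the measured compounds differs in a single place, so no measured step exists to lean on.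

Compound 4 `COc1ccc(CNc2nc([SeH])nc3ccccc23)cc1` is the next compound in the series. Relative to compound 1 the change is hydrogen in place of methyl on a selenium, a hydrogen in place of methyl on a selenium. Within the data shown here, with no comparable step among the measured compounds, the expectation for the step from compound 1 to compound 4 in this assay is no change beyond the scatter, a 1.2-fold lower number from compound 1 to compound 4 (0.09 log units; within the scatter). Compound 4 is therefore expected to give about 60000 nM in this assay, within a range from 20000 nM to 180000 nM.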

Compound 4, concentration for 50% growth inhibition: 71600 nM
For compound 4 the middle estimate is 1.2-fold (0.08 log units) below the measured one; low and high end bracket the measured number.
By their numbers in this assay, from the lowest: compound 2; then compounds 4 and 1 (each within the scatter of the next). At a limit, above all of these: compound 3.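

Within the data shown here, the first measured step at this position is flat in this assay: a 1.0-fold lower number from compound 1 to compound 4 (0.01 log units; within the scatter). Among these compounds, on the core of compound 1, hydrogen in place of methyl on a selenium therefore gives no separation beyond the scatter, so the methyl at this place is not required for the level of growth inhibition seen with compound 1, something the earlier compounds could not show without a pair differing in one place. Nothing among the data shown accounts for this flat step.

As far as these compounds go, only methyl and hydrogen have been compared on this selenium on this core, so it remains open whether an ethyl chain or a chain ending in a carboxylic acid at this place would separate from them in this assay. From the compounds shown here alone, it also remains open whether hydrogen in place of methyl on a selenium gives the same result on the core of compound 2.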